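The compounds below may be only part of what the source reports. "The series", "measured", "known", "first", "only" and "open" are said of these compounds alone.

Measured compounds:
compound 1, `CCCCOC(=O)[C@@]12C[C@@H]1[C@@H](n1cnc3c(NC)nc(C#Cc4ccc(Cl)s4)nc31)[C@H](O)[C@@H]2O`, 17.5 nM
compound 2, `CNc1nc(C#Cc2ccc(Cl)s2)nc2c1ncn2[C@H]1[C@H](O)[C@H](O)[C@]2(C(=O)OCCC(C)C)C[C@H]12`, 24.4 nM
compound 3, `CNc1nc(C#Cc2ccc(Cl)s2)nc2c1ncn2[C@H]1[C@H](O)[C@H](O)[C@]2(C(=O)OCCC3CCCCC3)C[C@H]12`, 770 nM

In an assay on HEK-293T cells for displacement of a labelled ligand from transmembrane domain-containing protein TMIGD3 (Homo sapiens), read by scintillation counting and radioligand binding, with stated times of 10 min and 90 min (a higher number here means a weaker inhibitor, a lower number a stronger inhibitor), compound 3 gives the highest number of the three. The step to compound 4, `CNc1nc(C#Cc2ccc(Cl)s2)nc2c1ncn2[C@H]1[C@H](O)[C@H](O)[C@]2(C(=O)OCc3ccccc3)C[C@H]12`, is phenyl in place of cyclohexylmethyl on a saturated chain carbon bound to an oxygen next to a carbonyl group. The measured steps that bear on it are a 44-fold higher number from compound 1 to compound 3 (1.64 log units; beyond the scatter) and a 32-fold higher number from compound 2 to compound 3 (1.50 log units; beyond the scatter): both show that the chain carrying the cyclohexyl ring sits far weaker than the shorter open chains of compound 1 and compound 2. Within the data shown here, compound 4 removes that ring and carries an aromatic ring in its place, shorter by one chain carbon; a lower number than compound 3 is therefore expected in this assay, though the aromatic ring has no measured counterpart here. For compound 4 the estimate is 100 nM, between 25 nM and 400 nM, a step of a 7.7-fold lower number from compound 3 to compound 4 (0.89 log units; beyond the scatter).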

Compound 4, inhibition constant: 7.31 nM
Estimate against measurement, compound 4: 14-fold (1.14 log units) above; the whole stated range lies above it.
By their numbers in this assay, from the lowest: compound 4; then compounds 1 and 2 (each within the scatter of the next); then compound 3.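

In this assay the change to phenyl gives a 110-fold lower number from compound 3 to compound 4 (2.02 log units; beyond the scatter) at this place, so a six-membered ring here does not by itself weaken the compound. The open chains do not match it either, with a 3.3-fold lower number from compound 2 to compound 4 (0.52 log units; beyond the scatter) and a 2.4-fold lower number from compound 1 to compound 4 (0.38 log units; beyond the scatter) as modest steps beyond the scatter. Nothing given here explains these differences.

Ring type and chain length change together in this step, so the compounds shown cannot separate them. A 2-phenylethyl ester or a cyclohexyl ester directly on the oxygen would tell them apart.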